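The source may hold more compounds than are shown below. What is called first, only, known or untested is meant among the compounds shown, and "the series" means these compounds.

Of the compounds shown here, three built on one shared core have been measured in a functional assay on BE(2)-C cells (Homo sapiens) for inhibition, read by MTT assay, with a stated time of 72 h; a lower number here means a stronger inhibitor of growth, a higher number a weaker inhibitor of growth. Compound 1 `O=S(=O)(NCCNCc1cccc2ccccc12)c1cc(C(F)(F)F)cc(C(F)(F)F)c1` gives 19000 nM in this assay, compound 3 `CC(C)(C)c1ccc(CNCCNS(=O)(=O)c2cc(C(F)(F)F)cc(C(F)(F)F)c2)cc1` gives 14000 nM, and compound 2 `O=S(=O)(NCCCNCC1COc2ccccc2O1)c1cc(C(F)(F)F)cc(C(F)(F)F)c1` gives 2800 nM. Compound 2 thus shows the lowest number of the three, and its gaps to compound 3 and to compound 1 both lie beyond the scatter, so on these numbers it is the strongest inhibitor of growth in this assay. Going by the values given here, the one step between two compounds that differ in a single place, a 1.4-fold lower number from compound 1 to compound 3 (0.13 log units; within the scatter), exchanges one group for another on a saturated chain carbon bound to an amine nitrogen and leaves the number essentially unchanged.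

Compound 4 `COc1ccccc1CNCCCNS(=O)(=O)c1cc(C(F)(F)F)cc(C(F)(F)F)c1` has not yet been measured. It differs from compound 2 as follows: 2-methoxyphenyl in place of 2,3-dihydro-1,4-benzodioxin-2-yl on a saturated chain carbon bound to an amine nitrogen. Among the compounds with values here, the measured step bears on this only loosely: it shows that exchanging the group at this position can leave the number where it was, but it joins compounds 1 and 3, whose numbers stand far above that of compound 2, and no measured pair removes a group like the one that leaves here. A modest weakening beyond the scatter is therefore expected, while the wide range allows for none. Compound 4 is expected to give about 6000 nM, between 2000 nM and 18000 nM. The expected step is a 2.1-fold higher number from compound 2 to compound 4 (0.33 log units; beyond the scatter).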

Compound 4, concentration for 50% growth inhibition: 3600 nM
Compound 4: the middle estimate sits 1.7-fold (0.22 log units) above what was measured; low and high end bracket the measured number.
By their numbers in this assay, from the lowest: compounds 2 and 4 (each within the scatter of the next); then compounds 3 and 1 (each within the scatter of the next).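

In this assay, 2-methoxyphenyl in place of 2,3-dihydro-1,4-benzodioxin-2-yl on a saturated chain carbon bound to an amine nitrogen gives a 1.3-fold higher number from compound 2 to compound 4 (0.11 log units; within the scatter), so compound 4 keeps a number that cannot be told apart from that of compound 2, even though the six-membered non-aromatic ring with 2 hetero atoms has gone. The earlier step, a 1.4-fold lower number from compound 1 to compound 3 (0.13 log units; within the scatter), showed such an exchange only among the two compounds with the higher numbers, whereas this one shows that the low number of compound 2 does not depend on that non-aromatic ring and survives with a single methoxy group on the aromatic ring in its place. The data offer no measurement that would explain why the number stays put across this exchange.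

The compounds shown leave open whether a benzyl group without the methoxy, or one carrying a nitrile or a carboxylic acid instead, would hold the number in compound 4. They also leave open what a longer chain would do with the 2-methoxyphenyl group kept in place, since no pair shown differs in the chain alone.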